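Swapping the aryl ketone substituent in a chalcone-pyrazole series

The compounds below may be only part of what the source reports. "The series", "measured", "known", "first", "only" and "open" are said of these compounds alone.

Measured compounds:
- Compound 1 `COc1cc(-c2cc(/C=C/C(=O)c3ccc(N)cc3)[nH]n2)cc(OC)c1OC`: 1060 nM
- Compound 2 `COc1ccc(C(=O)/C=C/c2cc(-c3cc(OC)c(OC)c(OC)c3)n[nH]2)cc1`: 1580 nM

Within the data shown here, compound 2 gives 1580 nM in a functional assay on LOX IMVI cells (Homo sapiens) for inhibition, read by sulforhodamine B assay, with a stated time of 48 h (on this read-out higher numbers stand for weaker inhibition of growth and lower numbers for stronger inhibition of growth), the higher of the two numbers recorded, though its only neighbour, compound 1 with 1060 nM, sits within the scatter of it. Among the measured compounds shown here, the single measured step, a 1.5-fold higher number from compound 1 to compound 2 (0.17 log units; within the scatter), is the only comparison that changes a substituent on the aryl ketone, and it produced no shift beyond the scatter.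

Compound 3 `COc1cc(-c2cc(/C=C/C(=O)c3ccc(F)c(F)c3)[nH]n2)cc(OC)c1OC` is not yet measured. It differs from compound 2 in one place: 3,4-difluorophenyl in place of 4-methoxyphenyl on a carbonyl carbon. For the measured compounds named here, no measured step involves fluorine, so the expectation rests on the one step in hand, which altered the same ring and left the number essentially where it was. On that basis compound 3 is expected to show a step of a 1.1-fold lower number from compound 2 to compound 3 (0.02 log units; within the scatter), that is, no change beyond the scatter, with a wide range to reflect the absence of a direct precedent. Compound 3 is therefore estimated at 1500 nM, between 500 nM and 5000 nM.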

Compound 3, concentration for 50% growth inhibition: 3180 nM
For compound 3 the middle estimate is 2.1-fold (0.33 log units) below the measured one; low and high end bracket the measured number.
By their numbers in this assay, from the lowest: compounds 1, 2 and 3 (each within the scatter of the next, the first and the last beyond it).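

Among these compounds, the position on the carbonyl carbon now proves not wholly indifferent to what it carries: in this assay, the step with 3,4-difluorophenyl in place of 4-aminophenyl is a 3.0-fold higher number from compound 1 to compound 3 (0.48 log units; beyond the scatter) and is the first at this position to leave the scatter, though only modestly, and it goes toward weaker inhibition of growth. The step with 3,4-difluorophenyl in place of 4-methoxyphenyl, a 2.0-fold higher number from compound 2 to compound 3 (0.30 log units; within the scatter), stays within the scatter, so compound 2 cannot be told apart from compound 3 any more than from compound 1, and only the two ends of this short series separate. Nothing shown here accounts for the separation between compound 1 and compound 3, and no measurement bears on its cause.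

On these data alone, it remains open whether unsubstituted phenyl or 4-fluorophenyl on the carbonyl carbon would fall with compound 1 or with compound 3, which would show whether the separation follows the fluorines or the amino group. Equally open, as far as these compounds go, is whether 4-hydroxyphenyl or 4-dimethylaminophenyl at this place would hold the level of compound 1 or move beyond it in either direction.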